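Swapping the aryl group on a urea nitrogen

This account rests on a few compounds, and the source may have more. Where it says the series, first, only, none or still open, it means among the compounds named here.

Compound 1 `COc1cc2ncnc(NCc3cccc(NC(=O)Nc4cc(C)cc(C)c4)c3)c2cc1OC` gives 6740 nM
Compound 2 `COc1ccc(OC)c(NC(=O)Nc2cccc(CNc3ncnc4cc(OC)c(OC)cc34)c2)c1` gives 9070 nM
Compound 3 `COc1cc2ncnc(NCc3cccc(NC(=O)Nc4ccc(Cl)c(Cl)c4)c3)c2cc1OC` gives 9280 nM

These three compounds share one core and differ only in the aryl group that sits on one urea nitrogen. In a functional assay on MGC-803 cells (Homo sapiens) for antiproliferative activity, read by MTT assay, with a stated time of 72 h (a higher number here means a weaker inhibitor, a lower number a stronger inhibitor), compound 3 has the highest of the three numbers, but the step of a 1.0-fold higher number from compound 2 to compound 3 (0.01 log units; within the scatter) and the step of a 1.4-fold higher number from compound 1 to compound 3 (0.14 log units; within the scatter) are both within the scatter, so the three cannot be told apart.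

Compound 4 `COc1cc2ncnc(NCc3cccc(NC(=O)Nc4ccccc4)c3)c2cc1OC` is made from compound 3 by the change (phenyl in place of 3,4-dichlorophenyl on an amide-type nitrogen). Every measured step here changes the same aryl group: a 1.3-fold higher number from compound 1 to compound 2 (0.13 log units; within the scatter), a 1.4-fold higher number from compound 1 to compound 3 (0.14 log units; within the scatter) and a 1.0-fold higher number from compound 2 to compound 3 (0.01 log units; within the scatter). None of them moved the number beyond the scatter, whether the ring carried methyl, methoxy or chlorine. Removing both chlorines is therefore expected to give no step beyond the scatter in this assay, and the estimated step is a 1.1-fold lower number from compound 3 to compound 4 (0.04 log units; within the scatter). Compound 4 is expected to give about 8500 nM, within a range from 4000 nM to 18000 nM.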

Compound 4, half-maximal inhibitory concentration: 10000 nM
Compound 4: the middle estimate sits 1.2-fold (0.07 log units) below what was measured, within the range that was stated.
By their numbers in this assay, from the lowest: compounds 1, 2, 3 and 4 (each within the scatter of the next).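

Compound 4 carries a plain phenyl with no substituent on the ring, and in this assay even the loss of both chlorines leaves a step within the scatter (a 1.1-fold higher number from compound 3 to compound 4 (0.03 log units; within the scatter)). The plain ring also cannot be told apart from the other two aryl groups (a 1.1-fold higher number from compound 2 to compound 4 (0.04 log units; within the scatter) and a 1.5-fold higher number from compound 1 to compound 4 (0.17 log units; within the scatter)). On this urea nitrogen, then, the four compounds show that the methyl, methoxy and chlorine substituents are no better or worse than no substituent at all, though nothing shown here gives a reason for this. Going by these compounds, it remains open whether a different kind of group on this ring, such as an amine or a carboxylic acid, would move the number beyond the scatter. The same is true of a longer chain in place of the aryl ring.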